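Swapping an Amide for a Sulfonamide

The compounds below may be only part of what the source reports. "The series", "measured", "known", "first", "only" and "open" are said of these compounds alone.

Compound 1 `CCN(CC)C(=O)c1ccc(S(=O)(=O)N2CCC[C@@H](C(=O)N3CCN(c4nc(C(C)C)no4)CC3)C2)cc1` | 100 nM
Compound 2 `CCOC(=O)[C@@H]1CCCN(S(=O)(=O)c2ccc(S(=O)(=O)N3CCNCC3)cc2)C1` | > 30000 nM (a limit of the assay)

Within the data shown here, in a functional assay on MIA PaCa-2 cells (Homo sapiens) for inhibition, read by MTT assay, with a stated time of 7 days (a higher number here means a weaker inhibitor, a lower number a stronger inhibitor), compound 1 gives 100 nM and holds the only exact number so far. Compound 2 reads > 30000 nM and this is a limit, not a number. Compound 3 `CCN(CC)S(=O)(=O)c1ccc(S(=O)(=O)N2CCC[C@@H](C(=O)N3CCN(c4nc(C(C)C)no4)CC3)C2)cc1` keeps the core of compound 1 and carries diethylsulfamoyl in place of diethylcarbamoyl on an aromatic carbon, para to a large group. Among the measured compounds shown here, no measured pair shows what this swap does, so the expectation starts from compound 1 at 100 nM and allows wide margins. In this assay a small step towards weaker inhibition is expected, possibly none beyond the scatter. The expected change is a 1.5-fold higher number from compound 1 to compound 3 (0.18 log units; within the scatter) and remains an estimate. Compound 3 is estimated at 150 nM with 40 nM to 600 nM as its expected range.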

Compound 3, half-maximal inhibitory concentration: 50 nM
For compound 3 the middle estimate is 3.0-fold (0.48 log units) above the measured one, and the stated range covers the measured number.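

In this assay, among these compounds, replacing diethylcarbamoyl with diethylsulfamoyl gives a 2.0-fold lower number from compound 1 to compound 3 (0.30 log units; within the scatter) and so provides the first direct reading of a change at this position. On this aromatic carbon, para to a large group, the two groups cannot be told apart in this measurement, so the amide carbonyl of compound 1 can give way to a sulfonyl linkage without a loss of inhibition beyond the scatter. Nothing measured here explains why compound 1 and compound 3 read alike.

Going by these compounds, what a carboxylic acid, a simple amine or a longer chain such as dipropylsulfamoyl would do at this position remains open. Compound 2 differs from these compounds in more than one place and its reading is only a limit, so it cannot settle that question.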